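The source may report more compounds than this note shows. Statements on the series, on what has been measured and on what is new or still open speak of the compounds shown alone.

Working notes on the series. For the measured compounds named here, in a functional assay on HepG2 cells (Homo sapiens) for antiproliferative activity, read by MTT assay, with a stated time of 72 h (on this read-out higher numbers stand for weaker inhibition and lower numbers for stronger inhibition), compound 1 `O=C1O[C@H]([C@@H](O)Cn2cc(-c3cccc(O)c3)nn2)C(OCc2ccccc2)=C1OCc1ccccc1` gives 62700 nM, the highest of the three numbers so far. Compound 2 `O=C1O[C@H]([C@@H](O)Cn2cc(-c3cc(F)cc(F)c3)nn2)C(OCc2ccccc2)=C1OCc1ccccc1` gives 11600 nM and compound 3 `C[Si](C)(C)c1cn(C[C@H](O)[C@H]2OC(=O)C(OCc3ccccc3)=C2OCc2ccccc2)nn1` gives 24100 nM in this assay. Both measured steps start from compound 1 and replace the same group: a 5.4-fold lower number from compound 1 to compound 2 (0.73 log units; beyond the scatter) and a 2.6-fold lower number from compound 1 to compound 3 (0.42 log units; beyond the scatter), while a 2.1-fold higher number from compound 2 to compound 3 (0.32 log units; beyond the scatter). Compound 4 `Cc1ccc(S(=O)(=O)NCc2cn(C[C@H](O)[C@H]3OC(=O)C(OCc4ccccc4)=C3OCc3ccccc3)nn2)cc1` carries the change ((((4-methylphenyl)sulfonyl)amino)methyl in place of 3-hydroxyphenyl on an aromatic carbon). Both prior replacements of the 3-hydroxyphenyl lowered the number, so a modest lowering beyond the scatter is expected here too, estimated as a 2.9-fold lower number from compound 1 to compound 4 (0.45 log units; beyond the scatter). Compound 4 is therefore expected to give about 22000 nM, within a range of 8000 nM to 60000 nM.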

Compound 4, half-maximal inhibitory concentration: 24900 nM
Compound 4: middle estimate off by 1.1-fold (0.05 log units), on the low side, within the range that was stated.
By their numbers in this assay, from the lowest: compound 2; then compounds 3 and 4 (each within the scatter of the next); then compound 1.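

In this assay, the aromatic carbon next to the ring nitrogen also accepts the larger (((4-methylphenyl)sulfonyl)amino)methyl group, with a 2.5-fold lower number from compound 1 to compound 4 (0.40 log units; beyond the scatter). Size of the entering group does not order the numbers: the much smaller silicon-bearing group gives no separation, with a 1.0-fold higher number from compound 3 to compound 4 (0.01 log units; within the scatter), while the 3,5-difluorophenyl group keeps the lowest number, with a 2.1-fold higher number from compound 2 to compound 4 (0.33 log units; beyond the scatter). No measurement available here accounts for these steps. On these data alone, whether an amine or a carboxylic acid on this carbon would lower the number further remains open, as does the contribution of the sulfonyl part of compound 4.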